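Benzyl for chloroaryl on the triazole of compound 3

This account rests on a few compounds, and the source may have more. Where it says the series, first, only, none or still open, it means among the compounds named here.

Measured so far in a functional assay on the whole organism (strain C57B/6) with Mus musculus as the target, in the maximal electroshock model; on this read-out lower numbers stand for an effect already at smaller amounts and higher numbers for an effect only at larger amounts of compound:
- compound 1, `CCCCCCOc1ccc(-n2cnnc2-c2ccc(F)cc2)cc1`, gives 22 mg/kg
- compound 2, `CCCCCCOc1ccc(-n2cnnc2-c2ccc(Cl)cc2)cc1`, gives 19.7 mg/kg
- compound 3, `CCCCCCOc1ccc(-n2cnnc2-c2ccccc2Cl)cc1`, gives 13.2 mg/kg

Compound 3 stands at the low end of the three numbers, separated from compound 2 by a 1.5-fold lower number from compound 2 to compound 3 (0.17 log units; within the scatter) and from compound 1 by a 1.7-fold lower number from compound 1 to compound 3 (0.22 log units; within the scatter), both within the scatter, so no ranking among the three is supported; a 1.1-fold lower number from compound 1 to compound 2 (0.05 log units; within the scatter) is likewise within the scatter.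

Compound 4, `CCCCCCOc1ccc(-n2cnnc2Cc2ccccc2)cc1`, differs from compound 3 by benzyl in place of 2-chlorophenyl on an aromatic carbon. Going by the values given here, none of the measured steps bears directly on this change: all three swap a halogen or its position on the aryl ring while keeping the aryl attached directly to the shared core, and all three stayed within the scatter. With no step beyond the scatter in this assay, the working expectation is that compound 4 also stays within the scatter of compound 3, with a 1.2-fold higher number from compound 3 to compound 4 (0.08 log units; within the scatter) as the expected step. For compound 4 the estimate is 16 mg/kg, with a range from 8 mg/kg to 35 mg/kg.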

Compound 4, dose for half-maximal effect: 19 mg/kg
Compound 4: the middle estimate sits 1.2-fold (0.07 log units) below what was measured; measured number inside the range.
By their numbers in this assay, from the lowest: compounds 3, 4, 2 and 1 (each within the scatter of the next).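

In this assay, this position on the shared core also takes benzyl, which puts a carbon between the core and the aromatic ring, and the number stays within the scatter of all three directly attached aryl compounds: a 1.4-fold higher number from compound 3 to compound 4 (0.16 log units; within the scatter), a 1.0-fold lower number from compound 2 to compound 4 (0.02 log units; within the scatter) and a 1.2-fold lower number from compound 1 to compound 4 (0.06 log units; within the scatter). The earlier steps shown here only moved or swapped a halogen on a directly attached aryl, whereas this change removes the chlorine and the direct attachment together without a step beyond the scatter, so no ranking among the four compounds is supported. Nothing available explains why the numbers stay this close.

Open, on these data alone, is whether the position would stay within the scatter with a longer chain between the core and the phenyl ring, or with an amine or a carboxylic acid in place of the aromatic ring. Because benzyl differs from 2-chlorophenyl in two ways at once, the four compounds also do not separate the loss of chlorine from the added carbon.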